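The compounds below may be only part of what the source reports. "The series", "measured", "known", "first", "only" and "open" are said of these compounds alone.

Measured so far in an assay on cells for inhibition of protein deacetylase HDAC6 (Homo sapiens), read by fluorescence, with stated times of 10 min and 30 min; on this read-out lower numbers stand for stronger inhibition and higher numbers for weaker inhibition:
compound 1 `COc1ccc(SCc2ccc(C(=O)Nc3ccccc3N)cc2)cc1`: > 32000 nM
compound 2 `CCc1ccc(SCc2ccc(C(=O)Nc3ccccc3N)cc2)cc1`: > 32000 nM

Compound 1 shows only a limit of the assay, > 32000 nM. Compound 2 likewise shows only a limit, > 32000 nM. Both shown values sit at the same limit (the limit of > 32000 nM in this assay, at which 2 of the 2 values shown sit), so the step that the two limits leave unreadable from compound 1 to compound 2 cannot be read. Compound 3 `Cc1cc(C)cc(SCc2ccc(C(=O)Nc3ccccc3N)cc2)c1` differs from compound 2 by 3,5-dimethylphenyl in place of 4-ethylphenyl on a sulfur. The only step that bears on this change is a step that the two limits leave unreadable from compound 1 to compound 2, unreadable, so no direction or size of step in this assay can be drawn from the shown data. Compound 3 is estimated at 40000 nM (range 15000 nM to 120000 nM), an expected step that the limit leaves unreadable from compound 2 to compound 3, most likely again reported only as a limit.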

Compound 3, half-maximal inhibitory concentration: > 32000 nM
Compound 3: a limit, no number; the forecaster's own chance of this, stated with the estimate: 80%; the middle value is on the limit's open side.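

In this assay compound 3 gives > 32000 nM, a limit and not a number. For the compounds shown here, no step among compound 1, compound 2 and compound 3 can be read: the limit of > 32000 nM in this assay, at which 3 of the 3 values shown sit. Left open is whether any of the three differs from the others in this assay, and by how much.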